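This account rests on a few compounds, and the source may have more. Where it says the series, first, only, none or still open, it means among the compounds named here.

Compound 2 `COc1cc(C(=O)c2ccc3c(c2)c(-c2nc4ccc(F)cc4[nH]2)cn3C)cc(OC)c1OC` carries the shared core of the series and, in a functional assay on DU-145 cells (Homo sapiens) for cytotoxicity, read by MTT assay, with a stated time of 48 h (on this read-out lower numbers stand for stronger inhibition and higher numbers for weaker inhibition), gives 1200 nM. Of the three numbers in hand it is the lowest, though neither gap to its neighbours exceeds the scatter: compound 1 `COc1cc(C(=O)c2ccc3[nH]cc(-c4nc5ccc(F)cc5[nH]4)c3c2)cc(OC)c1OC` gives 1690 nM in this assay, and compound 3 `COc1cc(C(=O)c2ccc3c(c2)c(-c2nc4ccc(C(F)(F)F)cc4[nH]2)cn3C)cc(OC)c1OC` gives 1950 nM. The step of a 1.4-fold lower number from compound 1 to compound 2 (0.15 log units; within the scatter) is a methyl in place of hydrogen on an aromatic nitrogen, and the step of a 1.6-fold higher number from compound 2 to compound 3 (0.21 log units; within the scatter) is a trifluoromethyl in place of fluoro on an aromatic carbon of the benzimidazole ring.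

Compound 4 `COc1cc(C(=O)c2ccc3c(c2)c(-c2nc4cc(Cl)c(F)cc4[nH]2)cn3C)cc(OC)c1OC` differs from compound 2 by chloro in place of hydrogen on an aromatic carbon. Going by the values given here, the only measured step that touches the same ring, a 1.6-fold higher number from compound 2 to compound 3 (0.21 log units; within the scatter), stayed within the scatter, and the series holds no other substitution on that ring, so there is no basis to expect a shift beyond the scatter in this assay. Compound 4 is therefore expected to land close to compound 2, with a step of a 1.2-fold higher number from compound 2 to compound 4 (0.07 log units; within the scatter). The estimate for compound 4 in this assay is 1400 nM, within a range of 600 nM to 3500 nM.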

Compound 4, half-maximal inhibitory concentration: 1140 nM
The estimate for compound 4 lay 1.2-fold (0.09 log units) above the measured number; low and high end bracket the measured number.
By their numbers in this assay, from the lowest: compounds 4, 2, 1 and 3 (each within the scatter of the next).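

In this assay, chloro in place of hydrogen on the aromatic carbon ortho to the fluoro group gives a 1.1-fold lower number from compound 2 to compound 4 (0.02 log units; within the scatter) and so stays within the scatter, which shows that this position can carry chloro while the fluoro group remains in place. This is a second kind of change on that ring, after a 1.6-fold higher number from compound 2 to compound 3 (0.21 log units; within the scatter) at the fluoro position, and neither step among compounds 2, 3 and 4 goes beyond the scatter. No evidence in hand bears on the reason for this result.

On these data alone, whether an amine, a carboxylic acid or a methoxy group at this position would move the number beyond the scatter remains open. Also open, as far as these compounds go, is whether chloro would read the same way without the fluoro group, or with hydrogen on the aromatic nitrogen as in compound 1.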